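Working notes: replacing 5-chloro-2-hydroxyphenyl in compound 2

This account rests on a few compounds, and the source may have more. Where it says the series, first, only, none or still open, it means among the compounds named here.

Measured so far in a functional assay, read by Griess assay, with a stated time of 2.5 h (a higher number here means a weaker inhibitor, a lower number a stronger inhibitor), are two compounds:
- compound 1 (`COc1cc(OC)c(OC)cc1/C=C/C(=O)c1cc(OC(C)=O)ccc1OC(C)=O`) gives 2.37 ug/mL
- compound 2 (`COc1cc(OC)c(OC)cc1/C=C/C(=O)c1cc(Cl)ccc1O`) gives 2.32 ug/mL

Compound 2 stands within the usual scatter of compound 1, and the two cannot be ranked. Compound 3 (`COc1cc(OC)c(OC)cc1/C=C/C(=O)c1ccc(Br)cc1`) has not yet been measured in this assay. It carries 4-bromophenyl in place of 5-chloro-2-hydroxyphenyl on a carbonyl carbon. Among the compounds with values here, no measured step shows what such a replacement does. Only a slight move towards a higher number is expected, with no change beyond the scatter. The expected step is a 1.3-fold higher number from compound 2 to compound 3 (0.11 log units; within the scatter) and remains a rough estimate. The value of compound 3 is estimated at 3 ug/mL (expected range 1.2 ug/mL to 7.5 ug/mL).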

Compound 3, half-maximal inhibitory concentration: 2.22 ug/mL
Estimate against measurement, compound 3: 1.4-fold (0.13 log units) above; the range from low to high includes it.
By their numbers in this assay, from the lowest: compounds 3, 2 and 1 (each within the scatter of the next).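

In this assay, 4-bromophenyl in place of 5-chloro-2-hydroxyphenyl on the carbonyl carbon gives a 1.0-fold lower number from compound 2 to compound 3 (0.02 log units; within the scatter), the first step readable at this position. A group with 0 hydrogen-bond donors therefore reads the same here as one with a hydroxy group, within the scatter. No supporting data explain this outcome.

Because both the hydroxy group and the halogen change in this single step, their separate contributions remain unresolved. As far as these compounds go, whether plain phenyl, or a phenyl carrying an amine or a carboxylic acid, would move the number beyond the scatter also remains open.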